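A few compounds are considered here, and "the series" means these few. Any claim that something is new, unique, unknown or untested is made for them only; others in the source may bear on it.

Measured so far:
compound 1 `COc1cc2cc(Oc3ccc(NC(=O)Nc4ccccc4)cc3)c(C)nc2cc1OC` — in a functional assay on NCI/ADR-RES cells (Homo sapiens) for inhibition, read by sulforhodamine B assay, with a stated time of 48 h, tested at 10 uM (on this read-out lower numbers stand for a stronger effect and higher numbers for a weaker effect at the one concentration tested), compound 1 gives 84.3%
compound 2 `COc1cc2cc(Oc3ccc(NC(=O)Nc4ccc(C)cc4)cc3)c(C)nc2cc1OC` — in this assay compound 2 gives 107%

Going by the values given here, compound 2 stands highest of the two numbers; the one measured step, a number 22.7 percentage points higher from compound 1 to compound 2 (beyond the scatter), separates it from compound 1. Compound 3 `COc1cc2cc(Oc3ccc(NC(=O)Nc4ccc(C(F)(F)F)cc4)cc3)c(C)nc2cc1OC` follows from compound 2 by trifluoromethyl in place of methyl on an aromatic carbon. Among the compounds with values here, no measured step covers a trifluoromethyl, and the methyl-for-hydrogen step is a different change, so it gives no direct guide. In this assay the expected step is a number 7 percentage points lower from compound 2 to compound 3 (within the scatter), not beyond the scatter. Compound 3 is estimated at 100%, between 80% and 120%.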

Compound 3, a percentage reported as activity, at one concentration (the size of the read-out at that concentration, not a potency): 64.1%
Compound 3: the middle estimate sits 35.9 percentage points above what was measured; measured number below the stated range.
By their numbers in this assay, from the lowest: compound 3; then compound 1; then compound 2.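

In this assay, the aromatic carbon para to a large group proves sensitive in both directions: methyl weakens the effect, while trifluoromethyl gives a number 42.9 percentage points lower from compound 2 to compound 3 (beyond the scatter) and also a number 20.2 percentage points lower from compound 1 to compound 3 (beyond the scatter). Trifluoromethyl therefore takes the series past the unsubstituted compound 1, making compound 3 the strongest of the three at the one concentration tested. Nothing available accounts for this reversal. Still open, on these data alone, is whether a chlorine, a methoxy or a nitrile on this carbon would track with trifluoromethyl or with methyl. Three compounds cannot show whether the trend extends to such groups.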